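The source may hold more compounds than are shown below. What is called first, only, known or untested is meant among the compounds shown, and "the series" means these compounds.

Measured so far:
compound 1 `O=C(Nc1ccc(Oc2ccnc3[nH]ccc23)cc1)c1nn(-c2ccc(Br)cc2F)ccc1=O` — 12800 nM
compound 2 `COc1ccc(-n2ccc(=O)c(C(=O)Nc3ccc(Oc4ccnc5c4ccn5C)cc3)n2)cc1` — > 60000 nM

In a functional assay on PC-3 cells (Homo sapiens) for cytotoxicity, read by MTT assay, with a stated time of 72 h (on this read-out lower numbers stand for stronger inhibition and higher numbers for weaker inhibition), compound 1 gives 12800 nM. For compound 2 the result is only a limit of this assay, > 60000 nM; it sits at the limit of > 60000 nM in this assay, at which 1 of the 2 values shown sits, so no number is known for it, only that it is the weaker of the two shown. Compound 3 `Cn1ccc2c(Oc3ccc(NC(=O)c4nn(-c5ccc(Br)cc5F)ccc4=O)cc3)ccnc21` is not yet measured. It differs from compound 2 in one place, (4-bromo-2-fluorophenyl in place of 4-methoxyphenyl on an aromatic nitrogen). Going by the values given here, no measured step covers this change, so any expectation rests on compound 1, which carries the same group and gives 12800 nM. The step from compound 2 to compound 3 is expected to be a gain, an at least 3.0-fold lower number from compound 2 to compound 3 (0.47 log units; beyond the scatter). Compound 3 is estimated at 20000 nM, within 6000 nM to 60000 nM.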

Compound 3, half-maximal inhibitory concentration: 20500 nM
Compound 3: middle estimate off by 1.0-fold (0.01 log units), on the low side, within the range that was stated.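

Going by these compounds alone, replacing 4-methoxyphenyl with 4-bromo-2-fluorophenyl on the aromatic nitrogen gives an at least 2.9-fold lower number from compound 2 to compound 3 (0.46 log units; beyond the scatter), the first direct reading of this change in this assay. Going by these compounds, its true size remains unknown, since compound 2 has only a limit: the limit of > 60000 nM in this assay, at which 1 of the 3 values shown sits. Methyl in place of hydrogen on an aromatic nitrogen of the shared core gives a 1.6-fold higher number from compound 1 to compound 3 (0.20 log units; within the scatter), so the two compounds cannot be told apart here.

On these data alone, whether the bromine, the fluorine or both carry the first step remains open. So does how a 4-aminophenyl group would read at this position.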